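This account rests on a few compounds, and the source may have more. Where it says the series, first, only, none or still open, it means among the compounds named here.

In a functional assay on HT-29 cells (Homo sapiens) for cytotoxicity, read by sulforhodamine B assay (on this read-out lower numbers stand for stronger inhibition of growth and higher numbers for weaker inhibition of growth), compound 1 `CC1=CC[C@@H]([C@@](C)(O)CCCC(C)(C)NC(=S)N/N=C\c2ccccc2)CC1` gives 36500 nM, while compound 2 `CC1=CC[C@@H]([C@@](C)(O)CCCC(C)(C)NC(=S)N/N=C\c2ccccc2[N+](=O)[O-])CC1` gives 16800 nM, the lower of the two numbers. Compound 3 `CC1=CC[C@@H]([C@@](C)(O)CCCC(C)(C)NC(=S)N/N=C\c2cccc([N+](=O)[O-])c2)CC1` is still unmeasured and differs from compound 2 in one place: 3-nitrophenyl in place of 2-nitrophenyl on a carbon with a double bond to nitrogen. Among the compounds with values here, the only measured step that bears on this is a 2.2-fold lower number from compound 1 to compound 2 (0.34 log units; beyond the scatter), a modest change on adding the nitro group. Within the data shown here, no measured step shows what moving that group does, so no change beyond the scatter is expected, and the estimated step is a 1.2-fold higher number from compound 2 to compound 3 (0.08 log units; within the scatter). The estimate for compound 3 is 20000 nM, with an expected range of 9000 nM to 40000 nM.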

Compound 3, concentration for total growth inhibition: 57100 nM
Beside the measured number, compound 3's estimate is 2.9-fold (0.46 log units) below it, and the stated range ends below it.
By their numbers in this assay, from the lowest: compound 2; then compounds 1 and 3 (each within the scatter of the next).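

In this assay, the place of the nitro group matters: 3-nitrophenyl in place of 2-nitrophenyl gives a 3.4-fold higher number from compound 2 to compound 3 (0.53 log units; beyond the scatter). The stronger growth inhibition seen on adding nitro therefore holds for 2-nitrophenyl but does not carry over to 3-nitrophenyl, where adding the group gives a 1.6-fold higher number from compound 1 to compound 3 (0.19 log units; within the scatter). No measurement shown explains this difference between the two nitrophenyl groups. Still open, on these data alone, is whether an amine or a carboxylic acid in place of the nitro group of 2-nitrophenyl would give a similar number.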